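Aryl ring variation on the hydrazone carbon: compound 3

This account rests on a few compounds, and the source may have more. Where it says the series, first, only, none or still open, it means among the compounds named here.

The series shares the core shown in compound 1 `Cc1c(C(=O)N/N=C\c2ccccc2O)oc2cccc(O)c12` and varies the ring on the carbon with a double bond to nitrogen. In a functional assay on MGC-803 cells (Homo sapiens) for inhibition, read by MTT assay (on this read-out higher numbers stand for weaker inhibition and lower numbers for stronger inhibition), compound 1 gives 10600 nM. Compound 2 `Cc1c(C(=O)N/N=C\c2cccc(F)c2O)oc2cccc(O)c12` carries fluoro in place of hydrogen on an aromatic carbon; in this assay compound 2 gives 8350 nM. The step of a 1.3-fold lower number from compound 1 to compound 2 (0.10 log units; within the scatter) lies within the scatter, so compound 2 holds the lower of the two numbers without separating from compound 1.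

Compound 3 `Cc1ccc(O)c(/C=N\NC(=O)c2oc3cccc(O)c3c2C)c1` is not yet measured. It differs from compound 2 by 2-hydroxy-5-methylphenyl in place of 3-fluoro-2-hydroxyphenyl on a carbon with a double bond to nitrogen. For the measured compounds named here, the only measured step touching this ring, a 1.3-fold lower number from compound 1 to compound 2 (0.10 log units; within the scatter), shows that the fluorine did not move the number beyond the scatter. Going by the values given here, no measured pair speaks to the methyl group, so nothing supports a shift in either direction. Compound 3 is therefore expected to land near the two measured numbers in this assay. For compound 3 the expected step is a 1.1-fold higher number from compound 2 to compound 3 (0.06 log units; within the scatter). The estimate for compound 3 is 9500 nM, with a range from 4000 nM to 22000 nM.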

Compound 3, half-maximal inhibitory concentration: 5990 nM
Beside the measured number, compound 3's estimate is 1.6-fold (0.20 log units) above it; low and high end bracket the measured number.
By their numbers in this assay, from the lowest: compounds 3, 2 and 1 (each within the scatter of the next).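

In this assay the change to 2-hydroxy-5-methylphenyl on the carbon with a double bond to nitrogen gives a 1.4-fold lower number from compound 2 to compound 3 (0.14 log units; within the scatter) and, read as a methyl group added to the ring of compound 1, gives a 1.8-fold lower number from compound 1 to compound 3 (0.25 log units; within the scatter). For the compounds shown here, this is the first reading on a methyl group on this ring, and with the earlier fluoro step it makes two single substitutions on the ring of compound 1, neither of which separates from compound 1 beyond the scatter. No accompanying data bear on what lies behind these numbers.

Still open is whether any group on this ring can move the number beyond the scatter: the compounds shown carry only a fluoro or a methyl group as the added substituent, and an amine, a carboxylic acid or a longer chain such as butyl would test this position far more widely. All three compounds also keep the hydroxy group on this ring, so what a ring without that group gives remains an open question for the series.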